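Amide nitrogen substituent swap on the shared core

This account rests on a few compounds, and the source may have more. Where it says the series, first, only, none or still open, it means among the compounds named here.

Of the compounds shown here, two so far carry numbers in an assay for inhibition of 6-phosphofructo-2-kinase/fructose-2,6-bisphosphatase 3 (Homo sapiens), read by ADP-Glo, with a stated time of 2 h; a lower number here means a stronger inhibitor, a higher number a weaker inhibitor. Compound 1 `Cn1ccc2ccc(-c3cc(Nc4ccccc4S(N)(=O)=O)cc4nccnc34)cc21` gives 265 nM in this assay. Compound 2 `Cn1cc(NC(=O)c2ccncc2Nc2cc(-c3ccc4ccn(C)c4c3)c3nccnc3c2)cn1` gives 33 nM in this assay, the lower of the two numbers, and its gap to compound 1 lies beyond the usual scatter. Compound 3 `CC(=O)N1CCOC(CNC(=O)c2ccncc2Nc2cc(-c3ccc4ccn(C)c4c3)c3nccnc3c2)C1` has not yet been measured. It keeps the core of compound 2 and differs in one place: (4-acetylmorpholin-2-yl)methyl in place of 1-methyl-1H-pyrazol-4-yl on an amide-type nitrogen. Among the compounds with values here, no measured pair isolates a change of this kind, so the expectation rests on compound 2 alone and on the nature of the exchange, an aromatic group leaving and a larger non-aromatic ring with an acetyl group entering. A modest loss is expected, as the step of a 3.0-fold higher number from compound 2 to compound 3 (0.48 log units; beyond the scatter), since compound 2 gives 33 nM with the aromatic group in place. Compound 3 is estimated at 100 nM, with a range from 25 nM to 400 nM.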

Compound 3, half-maximal inhibitory concentration: 93 nM
The estimate for compound 3 lay 1.1-fold (0.03 log units) above the measured number, and the stated range covers the measured number.
By their numbers in this assay, from the lowest: compound 2; then compound 3; then compound 1.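

In this assay the substituent on the amide-type nitrogen can be exchanged wholesale at limited cost: (4-acetylmorpholin-2-yl)methyl in place of 1-methyl-1H-pyrazol-4-yl gives a 2.8-fold higher number from compound 2 to compound 3 (0.45 log units; beyond the scatter). An aromatic ring on this nitrogen is therefore not required for compound 3 to reach 93 nM, although the change does cost some inhibition relative to compound 2. No supporting measurement bears on why the step has this size.

The compounds shown leave open how much of the step belongs to the morpholine ring and how much to its acetyl group. A free secondary amine in place of the acetylated ring nitrogen, or a carboxylic acid on a longer chain at the amide-type nitrogen, would test how far this position accepts other groups.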